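The source may hold more compounds than are shown below. What is called first, only, known or untested is meant among the compounds shown, and "the series" means these compounds.

Working notes on the thioether series

All compounds share one core and differ only in the length of the saturated chain. Compound 1 `CCCCCSC[C@H](NC(C)=O)C(=O)CCl` carries the shortest chain, compound 2 `CCCCCCCSC[C@H](NC(C)=O)C(=O)CCl` a longer one, and compound 3 `CCCCCCCCCCSC[C@H](NC(C)=O)C(=O)CCl` the longest of those measured. In a functional assay on MOLT-3 cells (Homo sapiens) (on this read-out lower numbers stand for stronger inhibition and higher numbers for weaker inhibition), compound 1 gives 5400 nM, compound 2 gives 2500 nM, and compound 3 gives 3400 nM. Compound 3 therefore stands second highest of the three numbers; its nearest neighbour is compound 2 (a 1.4-fold higher number from compound 2 to compound 3 (0.13 log units; within the scatter)) and its furthest is compound 1 (a 1.6-fold lower number from compound 1 to compound 3 (0.20 log units; within the scatter)), so its number is separable from neither. For the measured compounds named here, the only resolved step in the set is a 2.2-fold lower number from compound 1 to compound 2 (0.33 log units; beyond the scatter).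

Compound 4 `CCCCCCCCCCCCCSC[C@H](NC(C)=O)C(=O)CCl` extends the chain once more: propyl in place of hydrogen on a saturated chain carbon, ten or more bonds along the chain from a sulfur. Going by the values given here, the steps that bear on this are the earlier chain extensions: a 2.2-fold lower number from compound 1 to compound 2 (0.33 log units; beyond the scatter) gave a modest gain, whereas a 1.4-fold higher number from compound 2 to compound 3 (0.13 log units; within the scatter) did not move the number beyond the scatter, and a 1.6-fold lower number from compound 1 to compound 3 (0.20 log units; within the scatter) likewise stayed within it. With the most recent extension showing no resolved change, a further one in this assay is expected to give no step beyond the scatter, a 1.2-fold higher number from compound 3 to compound 4 (0.07 log units; within the scatter). Compound 4 is estimated at 4000 nM, with a range of 1500 nM to 10000 nM.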

Compound 4, half-maximal inhibitory concentration: > 100000 nM
Compound 4 gave a limit, no number; the forecaster's own chance of this, stated with the estimate: 5%; middle value at least 25-fold (1.39 log units) from the limit.
By their numbers in this assay, from the lowest: compounds 2, 3 and 1 (each within the scatter of the next, the first and the last beyond it). At a limit, above all of these: compound 4.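

Working notes on the result

In this assay compound 4 gives > 100000 nM, which is a limit of the assay and not a number. The tolerance for chain length seen so far therefore does not extend indefinitely: propyl in place of hydrogen on a saturated chain carbon, ten or more bonds along the chain from a sulfur, brings a large step, an at least 29-fold higher number from compound 3 to compound 4 (1.46 log units; beyond the scatter), although the change between compound 2 and compound 3 stayed within the scatter, and the step remains large against each shorter chain, an at least 40-fold higher number from compound 2 to compound 4 (1.60 log units; beyond the scatter) and an at least 18-fold higher number from compound 1 to compound 4 (1.26 log units; beyond the scatter). These three steps are bounded from one side only, and compound 4 is the only compound at the limit: the limit of > 100000 nM in this assay, at which 1 of the 4 values shown sits.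

The compounds shown leave open whether the number climbs gradually or abruptly at chain lengths intermediate between those of compound 3 and compound 4. They also leave open whether a long chain carrying an amine or a carboxylic acid would keep the number in the range of compound 3 or follow compound 4 to the limit.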